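Swapping the Ring Amine for Sulfur on Compound 2

The compounds below may be only part of what the source reports. "The series", "measured", "known", "first", "only" and "open" are said of these compounds alone.

Compound 1 `Nc1nc(NCc2ccccc2)c2ncn(/C=C3/CC3(CO)CO)c2n1`: 19900 nM
Compound 2 `Nc1nc(NC2CCCC2)c2ncn(/C=C3/CC3(CO)CO)c2n1`: 71700 nM

Going by the values given here, in an ADME assay on BCBL1 cells (Homo sapiens) for cytotoxicity, with a stated time of 7 days (on this read-out lower numbers stand for higher toxicity in this test and higher numbers for lower toxicity in this test), compound 2 gives the higher of the two numbers, and the only measured step, a 3.6-fold higher number from compound 1 to compound 2 (0.56 log units; beyond the scatter), separates it from compound 1. Compound 3 `Nc1nc(SC2CCCC2)c2ncn(/C=C3/CC3(CO)CO)c2n1` differs from compound 2 by cyclopentylsulfanyl in place of cyclopentylamino on an aromatic carbon. Among the compounds with values here, no measured step touches this change: the one available step concerns the group on the nitrogen, not the replacement of that nitrogen by sulfur, so it gives little guidance. With nothing to point in either direction, the expectation for compound 3 is a number close to that of compound 2, with a 1.2-fold lower number from compound 2 to compound 3 (0.08 log units; within the scatter) expected to lie within the scatter. Compound 3 is therefore estimated at 60000 nM, in a range from 20000 nM to 150000 nM.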

Compound 3, half-maximal cytotoxic concentration: > 20000 nM
Compound 3 gave a limit, no number (the forecaster's own chance of this, stated with the estimate: 25%); the middle value is on the limit's open side.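

In this assay, compound 3 returned a limit and not a number: the limit of > 20000 nM in this assay, at which 1 of the 3 values shown sits. The step from compound 2 cannot be read, so this result does not show whether cyclopentylsulfanyl in place of cyclopentylamino on this aromatic carbon raises the number, lowers it or leaves it unchanged. The only direction available comes from the comparison with the benzylamino compound, with a number no lower from compound 1 to compound 3 (the limit leaves the size open), and this shows that the sulfur-linked cyclopentyl compound does not fall below compound 1 on this read-out.

On these data alone, the position of compound 3 relative to compound 2 remains open. So does how an oxygen link, as in cyclopentyloxy, or a methylene link, as in cyclopentylmethyl, would compare at the same aromatic carbon.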